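The source may hold more compounds than are shown below. What is called first, only, known or untested is meant among the compounds shown, and "the series" means these compounds.

Cytotoxicity across the series is read in an ADME assay on HEL cells (Homo sapiens) for cytotoxicity, with a stated time of 3 days; on this read-out lower numbers stand for higher toxicity in this test and higher numbers for lower toxicity in this test. Compound 1 `Cc1cc(-c2cccc(F)c2)c2ncc(CSCCc3ccccc3)n2c1` gives 35 ug/mL in this assay. Compound 3 `Cc1cc(-c2cccc(O)c2)cn2c(CSCCc3ccccc3)cnc12` gives 50 ug/mL in this assay. For compound 2 `Cc1cc(-c2cccs2)c2ncc(CSCCc3ccccc3)n2c1` this assay reports only a limit, > 50 ug/mL, so compound 2 stands at the upper edge of the numbers shown without a value of its own; this is the limit of > 50 ug/mL in this assay, at which 1 of the 3 values shown sits. Among the compounds with values here, the one measured step bearing on the present change is an at least 1.4-fold higher number from compound 1 to compound 2 (0.15 log units; that floor lies within the scatter), whose floor lies within the scatter. Compound 4 `Cc1cc(-c2cccc([N+](=O)[O-])c2)c2ncc(CSCCc3ccccc3)n2c1` differs from compound 2 by 3-nitrophenyl in place of thiophen-2-yl on an aromatic carbon. Within the data shown here, no measured step joins a nitro-bearing aryl group to any other member, so the expectation rests on the aryl swap already seen and on the two phenyl-bearing members, compound 1 at 35 ug/mL and compound 3 at 50 ug/mL, which sit within the scatter of each other. Compound 4 is expected to give an estimated 40 ug/mL in this assay, within a range from 20 ug/mL to 60 ug/mL. This expectation amounts to a step of an at least 1.2-fold lower number from compound 2 to compound 4 (0.09 log units; that floor lies within the scatter), expected to stay within the scatter.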

Compound 4, half-maximal cytotoxic concentration: 47 ug/mL
Estimate against measurement, compound 4: 1.2-fold (0.07 log units) below; the range from low to high includes it.
By their numbers in this assay, from the lowest: compounds 1, 4 and 3 (each within the scatter of the next).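

With 3-nitrophenyl on this aromatic carbon of the shared core, this assay shows a 1.3-fold higher number from compound 1 to compound 4 (0.13 log units; within the scatter), so a nitro group on this aryl ring gives no step beyond the scatter when set against fluoro. The change from the five-membered thiophen-2-yl to the six-membered, larger 3-nitrophenyl gives an at least 1.0-fold lower number from compound 2 to compound 4 (0.02 log units; that floor lies within the scatter), so this position now carries a group with more heavy atoms and more hydrogen-bond acceptors with no printed step beyond the scatter. Compound 2 is still held only as a limit, so this step has a floor and no exact size: the limit of > 50 ug/mL in this assay, at which 1 of the 4 values shown sits.

The steps shown all stay within the scatter, so they give no order among these aryl groups. On these data alone, whether an amine or a carboxylic acid on this aryl ring, or a longer chain in place of the aryl group, would move the number beyond the scatter stays open.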